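The compounds below may be only part of what the source reports. "The series", "measured", "known", "first", "only" and "open" are said of these compounds alone.

Working notes on the series built on the core of compound 1 `Nc1nc(NC2CC2)c2ncn(/C=C3/CC3(CO)CO)c2n1`. In an ADME assay on BCBL1 cells (Homo sapiens) for cytotoxicity, with a stated time of 7 days (a higher number here means that more compound is tolerated, a lower number that less compound is tolerated), compound 1 gives 71500 nM. Compound 2 `CC(C)CSc1nc(N)nc2c1ncn2/C=C1/CC1(CO)CO` stops at a limit of this assay: compound 2 gives > 20000 nM, a limit and not a number. Compound 3 `CCCCCOc1nc(N)nc2c1ncn2/C=C1/CC1(CO)CO` likewise reaches only a limit, as compound 3 gives > 20000 nM. On the numbers shown, compound 2 therefore stands at the limit of > 20000 nM in this assay, at which 2 of the 3 values shown sit; it cannot be ordered against compound 3, and its distance from compound 1 is not readable.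

The change from compound 2 to compound 4 `CCCCNc1nc(N)nc2c1ncn2/C=C1/CC1(CO)CO` is butylamino in place of isobutylsulfanyl on an aromatic carbon.

Measured steps touching this position are a step that the limit leaves unreadable from compound 1 to compound 2, a step that the limit leaves unreadable from compound 1 to compound 3 and a step that the two limits leave unreadable from compound 2 to compound 3. Within the data shown here, none of them gives a readable size, so no measured step sets the size or direction of the new one. Among the measured compounds shown here, compound 1, carrying cyclopropylamino where compound 4 carries butylamino, is the only compound with a number; in this assay compound 1 gives 71500 nM.

Compound 4 is therefore expected to be tolerated at about 50000 nM, within a range from 20000 nM to 150000 nM. The step that this estimate means, a step that the limit leaves unreadable from compound 2 to compound 4, is expected only and cannot be checked against a readable starting value.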

Compound 4, half-maximal cytotoxic concentration: > 20000 nM
Compound 4: no number, only a limit; the forecaster's own chance of this, stated with the estimate: 40%; the middle value does not contradict the limit.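

In this assay compound 4 gives > 20000 nM, a limit and not a number. Among these compounds, no step between compound 4 and compound 1, compound 2 or compound 3 can be read. Compound 2 stands at: the limit of > 20000 nM in this assay, at which 3 of the 4 values shown sit.

The compounds shown leave open whether butylamino, isobutylsulfanyl and pentyloxy differ at all in this assay, and how compound 2, compound 3 and compound 4 stand against compound 1.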